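Replacing a Trifluorophenyl Sulfonyl with a Methoxyphenyl Sulfonyl

The source may hold more compounds than are shown below. What is called first, only, known or untested is meant among the compounds shown, and "the series" means these compounds.

Of the compounds shown here, two sharing one core have been tested in a functional assay on SUP-B15 cells (Homo sapiens) for antiproliferative activity, with a stated time of 72 h; a higher number here means that more compound is needed for the effect, a lower number that less compound is needed. Compound 1, `COc1ccc(-c2c(Cl)c(=O)c3c(OC)cc(OC)cc3n2S(=O)(=O)c2ccc(OC)cc2)cc1`, gives 17900 nM in this assay. Compound 2, `COc1ccc(-c2cc(=O)c3c(OC)cc(OC)cc3n2S(=O)(=O)c2cc(F)c(F)c(F)c2)cc1`, reaches only the limit of the assay, reported as > 65500 nM. Within the data shown here, that means no number is known for compound 2, only that its value lies at the limit described by the limit of > 65500 nM in this assay, at which 1 of the 2 values shown sits, where one of the two results stands.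

Compound 3, `COc1ccc(-c2cc(=O)c3c(OC)cc(OC)cc3n2S(=O)(=O)c2ccc(OC)cc2)cc1`, has not yet been measured. Its difference from compound 2 is a single exchange, (4-methoxyphenyl in place of 3,4,5-trifluorophenyl on a sulfonyl sulfur), in words a 4-methoxyphenyl in place of a 3,4,5-trifluorophenyl on a sulfonyl sulfur. Among the measured compounds shown here, no measured pair shows the effect of this exchange directly, so the size of the step is open. Because compound 1 carries the same 4-methoxyphenyl sulfonyl and gives 17900 nM, compound 3 is expected to need less compound than compound 2, by a step of an at least 2.1-fold lower number from compound 2 to compound 3 (0.33 log units; beyond the scatter) that may just exceed the scatter. The estimate for compound 3 in this assay is 30000 nM, within a range from 10000 nM to 100000 nM.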

Compound 3, half-maximal effective concentration: > 82700 nM
Compound 3: no number, only a limit; the forecaster's own chance of this, stated with the estimate: 35%; middle value at least 2.7-fold (0.44 log units) away from the limit.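

In this assay compound 3 gives > 82700 nM as a limit of the assay and not as a number. The exchange of 3,4,5-trifluorophenyl for 4-methoxyphenyl on a sulfonyl sulfur therefore cannot be read, because compound 3, like compound 2, carries only a limit: the limit of > 82700 nM in this assay, at which 1 of the 3 values shown sits. Among these compounds, what the result does show concerns a different place: with the 4-methoxyphenyl sulfonyl kept, hydrogen in place of chloro on an aromatic carbon gives an at least 4.6-fold higher number from compound 1 to compound 3 (0.66 log units; beyond the scatter) and so, in this one pair, the compound with chloro is the one that needs less compound for the effect.

Among the compounds shown here, the chloro step is seen with only one group on the sulfonyl sulfur, so whether it holds with 3,4,5-trifluorophenyl there remains open, as does any ranking of the two sulfonyl groups. Also open, from the compounds shown here alone, is how a bromo or a methyl on that aromatic carbon would compare with chloro and hydrogen.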